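The compounds below may be only part of what the source reports. "The series", "measured", "known", "first", "only" and "open" are said of these compounds alone.

Working notes on a quinoxaline sulfone series. Compound 1 `O=S(=O)(c1ccc(Br)cc1)c1nc2ccccc2nc1N1CCCC1` gives 6070 nM in a functional assay on HL-60 cells (Homo sapiens) for cytotoxicity, read by MTT assay, with a stated time of 72 h; a lower number here means a stronger inhibitor, a higher number a weaker inhibitor. Compound 2 `O=S(=O)(c1ccc(F)cc1)c1nc2ccccc2nc1N1CCCC1` carries the change fluoro in place of bromo on an aromatic carbon and gives 12800 nM in this assay; the step of a 2.1-fold higher number from compound 1 to compound 2 (0.32 log units; beyond the scatter). Compound 3 `O=S(=O)(c1ccc(Br)cc1)c1nc2ccccc2nc1N1CCc2ccccc2C1` carries the change 1,2,3,4-tetrahydroisoquinolin-2-yl in place of pyrrolidin-1-yl on an aromatic carbon and gives 2610 nM in this assay; the step of a 2.3-fold lower number from compound 1 to compound 3 (0.37 log units; beyond the scatter). Compound 3 stands lowest of the three measured numbers.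

Compound 4 `O=S(=O)(c1ccc(F)cc1)c1nc2ccccc2nc1N1CCc2ccccc2C1` has not yet been measured in this assay. It differs from compound 3 by fluoro in place of bromo on an aromatic carbon, the same change made from compound 1 to compound 2; the two cores differ by 1,2,3,4-tetrahydroisoquinolin-2-yl in place of pyrrolidin-1-yl on an aromatic carbon, and the place of the halogen swap reads identically in both pairs. Within the data shown here, compound 4 is therefore expected to follow the earlier step, with a 2.1-fold higher number from compound 3 to compound 4 (0.32 log units; beyond the scatter) set beside a 2.1-fold higher number from compound 1 to compound 2 (0.32 log units; beyond the scatter), resting only on the one measured pair and on compound 3 at 2610 nM. The estimate for compound 4 is 5500 nM, expected between 2500 nM and 12000 nM, pending measurement.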

Compound 4, half-maximal inhibitory concentration: 4080 nM
Estimate against measurement, compound 4: 1.3-fold (0.13 log units) above, and the stated range covers the measured number.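

Carried onto the core of compound 3, fluoro in place of bromo gives a 1.6-fold higher number from compound 3 to compound 4 (0.19 log units; within the scatter) in this assay, and this agrees with the step on the core of compound 1: the same change on two cores in this assay, a 2.1-fold higher number (0.32 log units; beyond the scatter) from compound 1 to compound 2 and a 1.6-fold higher number (0.19 log units; within the scatter) from compound 3 to compound 4, 1.3-fold (0.13 log units) apart, within the scatter of two such steps. The other change, 1,2,3,4-tetrahydroisoquinolin-2-yl in place of pyrrolidin-1-yl, gives a 3.1-fold lower number from compound 2 to compound 4 (0.50 log units; beyond the scatter) with fluoro on the phenyl ring, and it also carries across: the same change on two cores in this assay, a 2.3-fold lower number (0.37 log units; beyond the scatter) from compound 1 to compound 3 and a 3.1-fold lower number (0.50 log units; beyond the scatter) from compound 2 to compound 4, 1.3-fold (0.13 log units) apart, within the scatter of two such steps. Across these four compounds each change therefore transfers between the two cores, but this is a single square of compounds in this assay, the halogen step on the core of compound 3 does not clear the scatter, and nothing here shows the same transfer on any further core.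

Only bromo and fluoro are shown on the phenyl ring, so it remains open how chloro, methoxy or a nitrile in their place would read. On these data alone, on the amine side, morpholine or an open-chain amine such as diethylamino in place of pyrrolidin-1-yl also remains open.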